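This account rests on a few compounds, and the source may have more. Where it says the series, first, only, none or still open, it means among the compounds named here.

Measured in a functional assay on MM1.S cells (Homo sapiens) for cytotoxicity, read by MTT assay, with a stated time of 48 h; on this read-out higher numbers stand for weaker inhibition and lower numbers for stronger inhibition:

- compound 1 `O=C(c1ccccc1)N(N=C1C(Cl)=C(Cl)C(Cl)=C1Cl)C(=O)c1ccccc1`: 2000 nM
- compound 2 `CC(C)(C)OC(=O)NN=C1C(Cl)=C(Cl)C(Cl)=C1Cl`: 600 nM

Of these two, compound 2 at 600 nM has the lower number and so the stronger inhibition, and its gap to compound 1 lies beyond the usual scatter. Compound 3 `O=C(NN=C1C(Cl)=C(Cl)C(Cl)=C1Cl)c1ccccc1` has not yet been measured. The change from compound 2 to compound 3 is phenyl in place of tert-butoxy on a carbonyl carbon, with phenyl in place of tert-butoxy on a carbonyl carbon.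

Among the measured compounds shown here, no measured pair differs in one place only, so there is no direct precedent for the size of this step, and any expectation is loose. Compound 1 also carries phenyl on a carbonyl carbon and gives 2000 nM, so a small move towards a higher number is expected in this assay, one that may well stay within the scatter. The estimated step is a 1.5-fold higher number from compound 2 to compound 3 (0.18 log units; within the scatter). For compound 3 the expected value is 900 nM, with an estimated range of 300 nM to 2700 nM.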

Compound 3, half-maximal inhibitory concentration: 800 nM
The estimate for compound 3 lay 1.1-fold (0.05 log units) above the measured number, and the stated range covers the measured number.
By their numbers in this assay, from the lowest: compounds 2 and 3 (each within the scatter of the next); then compound 1.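

In this assay, the carbonyl carbon now has its first reading from a pair differing in one place: phenyl in place of tert-butoxy gives a 1.3-fold higher number from compound 2 to compound 3 (0.12 log units; within the scatter), so this position tolerates the exchange of these two groups, a ring of carbon only for a branched group with an oxygen, without a change that can be separated from the scatter. The amide-type nitrogen also has its first such reading, with hydrogen in place of benzoyl giving a 2.5-fold lower number from compound 1 to compound 3 (0.40 log units; beyond the scatter), and of the two single-place steps now available, only this one lies beyond the scatter, although it is modest. Nothing available explains either step.

On these data alone, each position rests on a single pair, so neither result establishes a trend, and it remains open whether an aminomethyl group, a carboxylic acid or a longer alkyl chain on the carbonyl carbon would also stay within the scatter of compound 3. As far as these compounds go, on the amide-type nitrogen, it is also open whether acetyl in place of hydrogen would produce a step like the one seen with benzoyl.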